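Urea to amide: a change without a direct precedent

The source may hold more compounds than are shown below. What is called first, only, known or untested is meant among the compounds shown, and "the series" means these compounds.

Measured so far in a functional assay on SNB-75 cells (Homo sapiens) for inhibition, read by sulforhodamine B assay, with a stated time of 48 h; a lower number here means a stronger inhibitor of growth, a higher number a weaker inhibitor of growth:
compound 1 `COc1cc(-c2nn(-c3cccc(NC(=O)Nc4cc(C(F)(F)F)cc(C(F)(F)F)c4)c3)cc2-c2ccncc2)ccc1Cl` gives 2070 nM
compound 2 `COc1cc(-c2nn(-c3cccc(NC(=O)Nc4ccc(Cl)c(Cl)c4)c3)cc2-c2ccncc2)ccc1Cl` gives 5170 nM
compound 3 `O=C(Nc1cccc(-n2cc(-c3ccncc3)c(-c3ccc(Cl)c(O)c3)n2)c1)Nc1ccc(Cl)c(Cl)c1` gives 12200 nM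

Compound 2 stands second highest of these three numbers in this assay. Its nearest neighbour is compound 3, reached by a 2.4-fold higher number from compound 2 to compound 3 (0.37 log units; beyond the scatter); compound 1 lies furthest away, with a lower number than compound 2, but the two differ in more than one place, so only their two values can be compared.

The unmeasured compound 4 `COc1cc(-c2nn(-c3cccc(NC(=O)c4ccc(Cl)c(C(F)(F)F)c4)c3)cc2-c2ccncc2)ccc1Cl` differs from compound 2 by 4-chloro-3-(trifluoromethyl)phenyl in place of (3,4-dichlorophenyl)amino on a carbonyl carbon. For the measured compounds named here, none of the measured steps touches this part of the molecule: the only single-place step, from compound 2 to compound 3, concerns the group on the oxygen, and the comparison of compound 1 with compound 2 involves a different aryl group on an unchanged urea. Going by the values given here, the expectation for compound 4 therefore rests on no direct precedent and should be read as uncertain.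

Given this, compound 4 is expected to stay close to compound 2 in this assay, with a step of a 1.3-fold lower number from compound 2 to compound 4 (0.11 log units; within the scatter). The estimate for compound 4 is 4000 nM, within a range from 1500 nM to 11000 nM.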

Compound 4, concentration for total growth inhibition: 29200 nM
Compound 4: the middle estimate sits 7.3-fold (0.86 log units) below what was measured; the measured number lies above the stated range.
By their numbers in this assay, from the lowest: compound 1; then compound 2; then compound 3; then compound 4.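

In this assay, compound 4 is the first compound shown to change the urea itself, and the result is a 5.6-fold higher number from compound 2 to compound 4 (0.75 log units; beyond the scatter), making it a weaker inhibitor of growth than compound 2. This position therefore does not tolerate every change: replacing (3,4-dichlorophenyl)amino with 4-chloro-3-(trifluoromethyl)phenyl on the carbonyl carbon has a cost beyond the scatter. This single step both removes the amide-type nitrogen with its hydrogen-bond donor and brings in trifluoromethyl, so the two changes cannot be told apart.

Still open, from the compounds shown here alone, is how a methylamino group or a methylene group on the carbonyl carbon, each paired with the same 3,4-dichlorophenyl ring, would compare with compound 2. The data shown also give no reason for the step.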